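The source may report more compounds than this note shows. Statements on the series, on what has been measured and on what is new or still open speak of the compounds shown alone.

Measured in a functional assay on MNK45 cells (Homo sapiens) for cytotoxicity, read by MTT assay, with a stated time of 48 h; on this read-out higher numbers stand for weaker inhibition and lower numbers for stronger inhibition:

Compound 1 `C[C@H]1C(=O)OC[C@H]2[C@@H]1CC[C@@]2(C)O`: > 50000 nM, a limit of the assay
Compound 2 `C[C@@H]1C(=O)OC[C@H]2[C@@H]1C[C@H](O)[C@@]2(C)O`: > 50000 nM, a limit of the assay

Among the compounds with values here, neither compound gives a number on this read-out, so no step between measured compounds can be read. Compound 2 stands with compound 1 at the limit of > 50000 nM in this assay, at which 2 of the 2 values shown sit.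

The next compound is compound 3 `C[C@H]1C(=O)OC[C@H]2[C@@H]1C[C@H](O)[C@@]2(C)O`. The change is the two compounds have the same atoms and bonds and differ only in configuration as drawn: 1 of 5 stereo elements differ; a stereocentre at a saturated ring carbon is drawn S in compound 2 and R in compound 3. Nothing leaves and nothing enters: a stereocentre at a saturated ring carbon is drawn S in compound 2 and R in compound 3.

Within the data shown here, with no measured step to go on, the expectation rests on compound 2, whose limit is > 50000 nM. In this assay, no change beyond the scatter is expected, and neither direction is favoured. The expected step that the limit leaves unreadable from compound 2 to compound 3 is an estimate, and a weak one, since it starts from a limit and not from a number. The assay will most likely report only a limit again. Compound 3 is expected at 60000 nM, with an estimated range from 30000 nM to 120000 nM.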

Compound 3, half-maximal inhibitory concentration: > 50000 nM
Compound 3 was reported as a limit (the forecaster's own chance of this, stated with the estimate: 85%); the middle value does not contradict the limit.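

In this assay compound 3 gives > 50000 nM as a limit of the assay. No step can be read from compound 1 or compound 2 to compound 3: the limit of > 50000 nM in this assay, at which 3 of the 3 values shown sit.

The compounds shown leave open whether the change in configuration, or hydroxy in place of hydrogen on a saturated ring carbon, alters the result in this assay at all.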